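From Dichlorophenyl to Dimethoxyphenyl: What to Expect of Compound 4

The source may report more compounds than this note shows. Statements on the series, on what has been measured and on what is new or still open speak of the compounds shown alone.

Compound 1 `Nc1cc(N)c2nc(-c3ccccc3)c(Oc3ccc(Cl)c(Cl)c3)nc2c1`: < 100000 nM in a functional assay on PC-3 cells (Homo sapiens) for inhibition, read by sulforhodamine B assay, with a stated time of 48 h (a lower number here means that less compound is tolerated, a higher number that more compound is tolerated), a limit of the assay.
Compound 2 `CCOC(=O)[C@H](CCC(=O)O)NC(=O)c1ccc(CNc2nc3cc(N)cc(N)c3nc2-c2ccccc2)cc1`: < 100000 nM in this assay, a limit of the assay.
Compound 3 `Nc1cc(N)c2nc(-c3ccccc3)c(NCc3ccc(Cl)c(Cl)c3)nc2c1`: 19100 nM in this assay.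

Within the data shown here, compound 3 therefore holds the only number among the three values shown, since the other two sit at a limit (the limit of < 100000 nM in this assay, at which 2 of the 3 values shown sit). Compound 4 `COc1ccc(CNc2nc3cc(N)cc(N)c3nc2-c2ccccc2)cc1OC` differs from compound 3 in one place: 3,4-dimethoxyphenyl in place of 3,4-dichlorophenyl on a saturated chain carbon bound to a nitrogen on an aromatic ring. Among the measured compounds shown here, no step between measured compounds is known, so there is nothing to gauge the change against. The step from compound 3 to compound 4 is expected to be a modest loss, estimated as a 2.1-fold higher number from compound 3 to compound 4 (0.32 log units; beyond the scatter). Compound 4 is expected to give about 40000 nM in this assay, with a range from 12000 nM to 130000 nM.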

Compound 4, concentration lethal to 50% of the cells: 83200 nM
Compound 4: middle estimate off by 2.1-fold (0.32 log units), on the low side, within the range that was stated.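

Among these compounds, the exchange of 3,4-dichlorophenyl for 3,4-dimethoxyphenyl on a saturated chain carbon bound to a nitrogen on an aromatic ring gives the first readable step at this position in this assay: a 4.4-fold higher number from compound 3 to compound 4 (0.64 log units; beyond the scatter). The number at this position therefore depends on the group it carries. Steps involving the other compounds cannot be read: the limit of < 100000 nM in this assay, at which 2 of the 4 values shown sit.

The compounds shown leave open how an unsubstituted phenyl, a pyridine or a carboxylic acid would fare at this position. They also leave open whether chlorine or methoxy alone would produce this step.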